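The compounds below may be only part of what the source reports. "The series", "measured", "known", "first", "only" and "open" are said of these compounds alone.

Working notes on the aryl-ether series around the shared core of compound 1 `CCOC(=O)c1cc(-c2cccc(OCc3cccc(F)c3)c2)on1`.

In an ADME assay on Vero cells (Chlorocebus sabaeus) for cytotoxicity, with a stated time of 72 h (a higher number here means a weaker inhibitor, a lower number a stronger inhibitor), compound 1 gives only a limit, > 128000 nM. Compound 2 `CCOC(=O)c1cc(-c2cccc(OCc3cccc(N)c3)c2)on1` likewise gives only a limit in this assay, > 128000 nM. The step from compound 1 to compound 2, amino in place of fluoro on an aromatic carbon, therefore cannot be sized: a step that the two limits leave unreadable from compound 1 to compound 2. Among the compounds with values here, the one piece of evidence on the measured values is the limit of > 128000 nM in this assay, at which 2 of the 3 values shown sit; it shows both substituted benzyl ethers ending at the ceiling of this assay, with no number in between to work from.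

Compound 3 `CCOC(=O)c1cc(-c2cccc(OCc3ccccc3F)c2)on1` stands without any number in this assay: "not determined" (no result reported). The next member, compound 4 `CCOC(=O)c1cc(-c2cccc(OCc3ccccc3[N+](=O)[O-])c2)on1`, differs from compound 3 by nitro in place of fluoro on an aromatic carbon, in words nitro in place of fluoro on an aromatic carbon.

Within the data shown here, no measured step bears directly on this change, and neither neighbour gives a number against which a direction could be read. Expectation rests on compound 1 and compound 2 sitting at the limit (the limit of > 128000 nM in this assay, at which 2 of the 3 values shown sit). On that basis compound 4 is expected to sit at or near the limit as well, estimated at 150000 nM with a range of 60000 nM to 400000 nM in this assay.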

Compound 4, half-maximal inhibitory concentration: > 128000 nM
Compound 4: only a limit was reported; the forecaster's own chance of this, stated with the estimate: 85%; the middle value lies beyond the limit too.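

Compound 4 also gives only a limit in this assay, > 128000 nM. No new step can be read: those from compound 1 and compound 2 to compound 4 join limits only, so they cannot be sized. The compounds shown leave open whether fluoro, amino or nitro separates at all in this assay, with every numeric reading confined to: the limit of > 128000 nM in this assay, at which 3 of the 4 values shown sit.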